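Thiophen-2-yl for phenyl: a step without a measured precedent

This account rests on a few compounds, and the source may have more. Where it says the series, first, only, none or still open, it means among the compounds named here.

Going by the values given here, compound 1 `CC1=CC[C@H](C(C)(C)NC(=S)N/N=C/c2ccccc2)CC1` is the only member of the series with a number: in a functional assay on PC-3 cells (Homo sapiens) for inhibition, read by sulforhodamine B assay, with a stated time of 48 h (on this read-out lower numbers stand for stronger inhibition of growth and higher numbers for weaker inhibition of growth), compound 1 gives 1300 nM. Compound 2 `CC1=CC[C@H](C(C)(C)NC(=S)N/N=C/c2ccccc2O)CC1` reaches a limit of the assay, < 40 nM, and not a number (the limit of < 40 nM in this assay, at which 1 of the 2 values shown sits). Among the compounds with values here, the one measured step, an at least 32-fold lower number from compound 1 to compound 2 (1.51 log units; beyond the scatter), is a hydroxy in place of hydrogen on an aromatic carbon. Compound 3 `CC1=CC[C@H](C(C)(C)NC(=S)N/N=C/c2cccs2)CC1` differs from compound 1 in another place: thiophen-2-yl in place of phenyl on a carbon with a double bond to nitrogen. Within the data shown here, no measured step touches this change, so no step beyond the scatter is expected in this assay in either direction. Compound 3 is therefore estimated at 1300 nM, between 400 nM and 4000 nM, a step of no change at the digits printed from compound 1 to compound 3 (within the scatter).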

Compound 3, concentration for 50% growth inhibition: 17800 nM
Estimate against measurement, compound 3: 14-fold (1.14 log units) below; the whole stated range lies below it.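

In this assay, the group on a carbon with a double bond to nitrogen is not freely exchangeable: thiophen-2-yl in place of phenyl gives a 14-fold higher number from compound 1 to compound 3 (1.14 log units; beyond the scatter). This position therefore responds to the ring itself as well as to a hydroxy on it, and thiophen-2-yl in place of 2-hydroxyphenyl gives an at least 440-fold higher number from compound 2 to compound 3 (2.64 log units; beyond the scatter). Compound 2 stands at a limit and not at a number, so that step gives only a bound: the limit of < 40 nM in this assay, at which 1 of the 3 values shown sits.

Open, from the compounds shown here alone, is whether a hydroxy on the thiophen-2-yl ring would lower the number as it does on phenyl. Also open, going by these compounds, is how furan-2-yl or pyridin-2-yl would read at this place.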